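Swapping One Aryl Group: Expected Effect on Clearance

A few compounds are considered here, and "the series" means these few. Any claim that something is new, unique, unknown or untested is made for them only; others in the source may bear on it.

Measured so far:
compound 1 `O[C@]1(Cc2cc(-c3cn[nH]c3)on2)CC[C@@H](Cc2ccc(C(F)(F)F)cc2)CC1`: 4 mL/min/kg
compound 2 `O=C(c1cc(-c2ccc(=O)[nH]c2)on1)N1CCC(Cc2ccc(F)cc2)CC1`: 19.7 mL/min/kg
compound 3 `O=C(Nc1ccc2[nH]c(=O)oc2c1)C(=O)N1CCN(c2ccc(Cl)cc2)CC1`: 7.2 mL/min/kg

In an ADME assay on the whole organism (Rattus norvegicus, strain Sprague-Dawley) for pharmacokinetics, using cassette dosing, at a dose of 0.5 mg/kg by the intravenous route (on this read-out lower numbers stand for slow clearance and higher numbers for fast clearance), compound 3 gives 7.2 mL/min/kg, the second highest of the three numbers. Compound 1 lies within the usual scatter of compound 3, so the two cannot be told apart, while compound 2 sits beyond the scatter on the faster side.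

Compound 4 `COc1ccc(N2CCN(C(=O)C(=O)Nc3ccc4[nH]c(=O)oc4c3)CC2)cc1F` is the next compound, differing from compound 3 in one place: 3-fluoro-4-methoxyphenyl in place of 4-chlorophenyl on an amine nitrogen in a ring. Among the measured compounds shown here, no step between measured compounds shows what this change does, so the expectation rests on compound 3 alone. A small rise in clearance is expected, with the step of a 1.4-fold higher number from compound 3 to compound 4 (0.14 log units; within the scatter) likely at or just beyond the edge of the scatter. For compound 4 the estimate is 10 mL/min/kg, within a range of 5 mL/min/kg to 22 mL/min/kg.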

Compound 4, clearance: 101 mL/min/kg
Estimate against measurement, compound 4: 10-fold (1.00 log units) below; the whole stated range lies below it.
By their numbers in this assay, from the lowest: compounds 1 and 3 (each within the scatter of the next); then compound 2; then compound 4.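

Swapping the aryl group on this ring nitrogen is far from a neutral exchange: in this assay, 3-fluoro-4-methoxyphenyl in place of 4-chlorophenyl gives a 14-fold higher number from compound 3 to compound 4 (1.15 log units; beyond the scatter). Among the compounds shown here, the earlier compounds each differed in several places, so only this step shows that a change at this one position can move clearance so strongly.

Going by these compounds, whether the methoxy or the fluoro part carries the step stays open, and 4-methoxyphenyl or 3-fluorophenyl on the same nitrogen would separate the two. Nothing available here explains the size of the rise.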